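One added methyl on compound 2

A few compounds are considered here, and "the series" means these few. Any claim that something is new, unique, unknown or untested is made for them only; others in the source may bear on it.

- compound 1 `Cc1cc(CN(CC2CCCC2)C(CC(=O)O)c2ccc(Cl)cc2)ccc1OCCN1C(=O)CCC1=O`: 28.9 nm/s
- compound 2 `Cc1cc(CN(CC2CCCC2)[C@@H](CC(=O)O)c2ccc(Cl)cc2)ccc1OCCN1C(=O)CCC1=O`: 18.1 nm/s

Among the measured compounds shown here, in an ADME assay on Caco-2 cells (Homo sapiens) for permeability, read by LC-MS, with a stated time of 2 h (on this read-out higher numbers stand for higher permeability and lower numbers for lower permeability), compound 2 stands within the scatter of compound 1, the only other measured compound, with a 1.6-fold lower number from compound 1 to compound 2 (0.20 log units; within the scatter) between them. Compound 3 `CCc1cc(CN(CC2CCCC2)[C@@H](CC(=O)O)c2ccc(Cl)cc2)ccc1OCCN1C(=O)CCC1=O` differs from compound 2 by methyl in place of hydrogen on a saturated chain carbon bound to an aromatic carbon at one place: methyl in place of hydrogen on a saturated chain carbon bound to an aromatic carbon, so methyl becomes ethyl. For the measured compounds named here, the one measured step concerns only the fact that one of compounds 1 and 2 is drawn with a defined configuration and the other without, at the place where they differ and no measurement covers a change like this one, so no shift beyond the scatter is expected. The expected 1.2-fold higher number from compound 2 to compound 3 (0.08 log units; within the scatter) stays within the scatter. Compound 3 is expected at 22 nm/s within an estimated range of 10 nm/s to 48 nm/s on this read-out.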

Compound 3, apparent permeability: 57.3 nm/s
Compound 3: middle estimate off by 2.6-fold (0.42 log units), on the low side; measured number above the stated range.
By their numbers in this assay, from the lowest: compounds 2, 1 and 3 (each within the scatter of the next, the first and the last beyond it).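

In this assay, the methyl to ethyl change gives a 3.2-fold higher number from compound 2 to compound 3 (0.50 log units; beyond the scatter), so at this place, a saturated chain carbon bound to an aromatic carbon, adding one carbon moves the number beyond the scatter. The only earlier step changed just how a stereocentre was drawn and stayed within the scatter, so this is the first step shown with a change in atoms, and the first beyond the scatter. Nothing shown here bears on why the number rises.

The compounds shown leave open whether a longer chain such as propyl would raise the number further or reverse the step. A single step also cannot say how a hydroxyl or an amine on this carbon would read.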